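Halogen swap on the fused ring of compound 2

The source may hold more compounds than are shown below. What is called first, only, known or untested is meant among the compounds shown, and "the series" means these compounds.

Measured so far:
compound 1 `O=C1Nc2ccc(F)cc2/C1=N/NC(=S)Nc1ccc(Cl)cc1`: 34000 nM
compound 2 `O=C1/C(=N\NC(=S)Nc2ccc(Cl)cc2)c2cc(F)ccc2N1Cc1ccc(F)cc1`: 154000 nM

In a functional assay on L1210 cells (Mus musculus), with a stated time of 48 h (on this read-out lower numbers stand for stronger inhibition and higher numbers for weaker inhibition), compound 2 gives 154000 nM, the highest of the two numbers shown. Compound 1 gives 34000 nM. Among the measured compounds shown here, the single measured step is a 4.5-fold higher number from compound 1 to compound 2 (0.66 log units; beyond the scatter), and it concerns the substituent on the ring nitrogen. Compound 3 `O=C1/C(=N\NC(=S)Nc2ccc(Cl)cc2)c2cc(Br)ccc2N1Cc1ccc(F)cc1` is not yet measured; it differs from compound 2 by bromo in place of fluoro on an aromatic carbon. For the measured compounds named here, no measured step bears on this position, so there is nothing to lean on. The expected step of no change at the digits printed from compound 2 to compound 3 (within the scatter) is therefore none beyond the scatter. Compound 3 is estimated at 154000 nM, with a range from 55000 nM to 430000 nM.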

Compound 3, half-maximal inhibitory concentration: 196000 nM
For compound 3 the middle estimate is 1.3-fold (0.10 log units) below the measured one; low and high end bracket the measured number.
By their numbers in this assay, from the lowest: compound 1; then compounds 2 and 3 (each within the scatter of the next).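

In this assay, bromo in place of fluoro on this aromatic carbon gives a 1.3-fold higher number from compound 2 to compound 3 (0.10 log units; within the scatter), so the two halogens are not told apart here while the 4-fluorobenzyl group stays on the ring nitrogen. Among the compounds shown here, the earlier step concerned only that nitrogen, and this is the first reading at the halogen position. No measurement at hand accounts for this result.

On these data alone, whether an amine or a methoxy group on this carbon would read differently stays open. So does whether bromo would behave alike with the amide hydrogen of compound 1 in place.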